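Amide substituent changes in one shared-core series

The source may report more compounds than this note shows. Statements on the series, on what has been measured and on what is new or still open speak of the compounds shown alone.

Compound 1, `COc1ccc2c(=O)c(/C=C/C(=O)NCc3ccc(F)cc3)coc2c1`: > 100000 nM
Compound 2, `CCOc1ccc(NC(=O)/C=C/c2coc3cc(OC)ccc3c2=O)cc1`: > 100000 nM
Compound 3, `COc1ccc(NC(=O)/C=C/c2coc3cc(OC)ccc3c2=O)cc1`: 13000 nM
Compound 4, `COc1ccc2c(=O)c(/C=C/C(=O)Nc3ccc(F)cc3)coc2c1`: not yet measured

Going by the values given here, in a functional assay on HeLa cells (Homo sapiens) for inhibition, read by MTT assay, with a stated time of 48 h (on this read-out lower numbers stand for stronger inhibition and higher numbers for weaker inhibition), compound 3 gives 13000 nM and is the only compound of the three measured that returns a number. Compound 1 reaches only > 100000 nM in this assay, which is a limit of the assay and not a number. Compound 2 likewise returns only the limit > 100000 nM. Compound 3 therefore stands alone as the one measurable point in this assay.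

Compound 4 differs from compound 3 by fluoro in place of methoxy on an aromatic carbon. Of the measured steps, the one closest in place is an at least 7.6-fold lower number from compound 2 to compound 3 (0.88 log units; beyond the scatter), a change of an alkoxy group on the same aromatic carbon; the other, an at least 7.6-fold lower number from compound 1 to compound 3 (0.88 log units; beyond the scatter), alters two parts of the amide substituent at once. Among the compounds with values here, no measured step sets methoxy directly against fluoro on an aromatic carbon. With the limit of > 100000 nM in this assay, at which 2 of the 3 values shown sit, marking where two of three compounds sit, the loss of the methoxy group from compound 3 is expected to cost activity: the step of a 3.1-fold higher number from compound 3 to compound 4 (0.49 log units; beyond the scatter) is expected in this assay. Compound 4 is thus estimated at 40000 nM, with a range from 10000 nM to 150000 nM, and a fair chance that only a limit is reported.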

Compound 4, half-maximal inhibitory concentration: 9680 nM
Compound 4: the middle estimate sits 4.1-fold (0.62 log units) above what was measured; the measured number lies below the stated range.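

In this assay, the change from 4-methoxyphenyl to 4-fluorophenyl gives a 1.3-fold lower number from compound 3 to compound 4 (0.13 log units; within the scatter), so at this place, para to a large group, methoxy and fluoro are not told apart and the methoxy oxygen is not required for a measurable number. Against ethoxy on the same carbon, fluoro gives an at least 10-fold lower number from compound 2 to compound 4 (1.01 log units; beyond the scatter), which leaves ethoxy as the one group shown here that separates from the others at this place. With fluorine kept on the aromatic ring, an at least 10-fold lower number from compound 1 to compound 4 (1.01 log units; beyond the scatter) isolates the 4-fluorophenyl to 4-fluorobenzyl difference on the amide nitrogen, which the comparison with compound 3 had mixed with a second change.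

Both large steps are bounded on one side only, since compound 1 and compound 2 each sit at a limit of the assay and not at a number: the limit of > 100000 nM in this assay, at which 2 of the 4 values shown sit. Open is how a plain hydrogen, a chloro group, an amine or a carboxylic acid would read at this place.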